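The compounds below may be only part of what the source reports. "The series", "measured", "known", "first", "only" and "open" are said of these compounds alone.

In a functional assay on HT-29 cells (Homo sapiens) for cytotoxicity, read by MTT assay, with a stated time of 48 h (on this read-out higher numbers stand for weaker inhibition and lower numbers for stronger inhibition), three compounds built on closely related cores have been measured, and a fourth awaits its value. Compound 1, `COc1cc(/C=C/C(=O)/C=C(/C=C/c2ccc(O)c(OC)c2)NCCO)ccc1O`, sits at the limit of this assay with > 100000 nM, a limit rather than a number. Compound 3, `COCCNC(=C\C(=O)/C=C/c1ccc(O)c(OC)c1)/C=C/c1ccc(O)c(OC)c1`, likewise returns only the limit > 100000 nM. Among the compounds with values here, compound 2, `COCCNC(=C\C(=O)/C=C/c1ccc(O)cc1)/C=C/c1ccc(O)cc1`, is the one compound with a number in this assay, giving 57400 nM. The difference between the cores of compound 2 and compound 3 is not broken down here.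

Compound 1 and compound 3 differ by one change, (hydrogen in place of methyl on an oxygen on a saturated carbon), and the step that the two limits leave unreadable from compound 3 to compound 1 cannot be read, because of the limit of > 100000 nM in this assay, at which 2 of the 3 values shown sit.

The unmeasured compound 4, `O=C(/C=C(/C=C/c1ccc(O)cc1)NCCO)/C=C/c1ccc(O)cc1`, arises from compound 2 by the same change, (hydrogen in place of methyl on an oxygen on a saturated carbon), made at a place described in the same words as for the pair of compound 3 and compound 1. Within the data shown here, since the one measured example of this change yields no readable size, the expectation for compound 4 rests chiefly on the value of compound 2 in this assay, 57400 nM, with the step taken as small. Compound 4 is therefore expected to give about 70000 nM in this assay, which would mean a step of a 1.2-fold higher number from compound 2 to compound 4 (0.09 log units; within the scatter), and a plausible span from 25000 nM to 200000 nM is estimated.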

Compound 4, half-maximal inhibitory concentration: 66200 nM
The estimate for compound 4 lay 1.1-fold (0.02 log units) above the measured number; low and high end bracket the measured number.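

In this assay, exchanging 2-methoxyethyl for 2-hydroxyethyl, with hydrogen in place of methyl on an oxygen on a saturated carbon, gives a 1.2-fold higher number from compound 2 to compound 4 (0.06 log units; within the scatter), so on the core of compound 2 the two ends of this step cannot be told apart. The same change from compound 3 to compound 1 cannot be read, because both of its values are limits and not numbers: the limit of > 100000 nM in this assay, at which 2 of the 4 values shown sit. As far as these compounds go, the series therefore holds a single readable example of this change, which shows what it does on the core of compound 2 and does not show that the same small step carries over to the core of compound 3, so any transfer from one core to the other remains untested by these values.

The compounds shown leave open how a 2-aminoethyl group, a chain ending in a carboxylic acid, or a longer chain such as 3-hydroxypropyl would read in place of the 2-hydroxyethyl group on either core. They also leave open whether any such group on the core of compound 1 would give a number rather than a limit.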